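From furan-3-yl to cyclohexyl on a shared core

This account rests on a few compounds, and the source may have more. Where it says the series, first, only, none or still open, it means among the compounds named here.

For the measured compounds named here, in an ADME assay on MT4 cells (Homo sapiens) for cytotoxicity, read by MTT assay, with a stated time of 96 h (on this read-out higher numbers stand for lower toxicity in this test and lower numbers for higher toxicity in this test), compound 2 `C/C(=N\NC(N)=S)c1ccc2[nH]c(-c3ccoc3)nc2c1` gives 86000 nM as the higher of the two numbers so far, and compound 1 `C/C(=N\NC(N)=S)c1ccc2[nH]c(-c3ccc(Cl)cc3)nc2c1` gives 2000 nM as the lower. Compound 3 `C/C(=N\NC(N)=S)c1ccc2[nH]c(C3CCCCC3)nc2c1` has not been measured and differs through cyclohexyl in place of furan-3-yl on an aromatic carbon on an aromatic carbon of the shared core. Going by the values given here, the one measured step at this place (a 43-fold higher number from compound 1 to compound 2 (1.63 log units; beyond the scatter)) was large, so a clear move is expected here too, downward in this assay but smaller than that step. The expected step is a 7.2-fold lower number from compound 2 to compound 3 (0.86 log units; beyond the scatter) in size. Compound 3 is estimated at 12000 nM (range 3000 nM to 50000 nM).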

Compound 3, half-maximal cytotoxic concentration: 48000 nM
The estimate for compound 3 lay 4.0-fold (0.60 log units) below the measured number; the range from low to high includes it.
By their numbers in this assay, from the lowest: compound 1; then compounds 3 and 2 (each within the scatter of the next).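

In this assay, cyclohexyl in place of furan-3-yl gives a 1.8-fold lower number from compound 2 to compound 3 (0.25 log units; within the scatter), so an aromatic ring at this place is not needed for a number this high, and these two different rings cannot be told apart here. Cyclohexyl in place of 4-chlorophenyl gives a 24-fold higher number from compound 1 to compound 3 (1.38 log units; beyond the scatter), which leaves compound 1 alone at the low end of the three. Nothing available explains that gap. Still open, on these data alone, is whether plain phenyl, without the chlorine, would read like compound 1 or like compound 2 and compound 3, and how an amine or a longer chain would read at this place.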